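The source may hold more compounds than are shown below. What is called first, only, known or untested is meant among the compounds shown, and "the series" means these compounds.

Measured in a functional assay on MCF cells (Homo sapiens) for antiproliferative activity, with a stated time of 72 h; on this read-out higher numbers stand for weaker inhibition and lower numbers for stronger inhibition:
Compound 1 `OC[C@H]1O[C@@H](n2cnc3c(NCc4ccc(F)cc4)ncnc32)[C@H](O)[C@@H]1O`: 21000 nM
Compound 2 `OC[C@H]1O[C@@H](n2cnc3c(NCc4cccc(O)c4O)ncnc32)[C@H](O)[C@@H]1O`: 5200 nM

Compound 2 has the lower of the two numbers, so it is the stronger inhibitor so far. Compound 3 `OC[C@H]1O[C@@H](n2cnc3c(NCc4cc(O)cc(O)c4)ncnc32)[C@H](O)[C@@H]1O` keeps the shared core and changes one group: 3,5-dihydroxyphenyl in place of 2,3-dihydroxyphenyl on a saturated chain carbon bound to a nitrogen on an aromatic ring. In words, it has 3,5-dihydroxyphenyl in place of 2,3-dihydroxyphenyl. For the measured compounds named here, only one measured step bears on this, a 4.0-fold lower number from compound 1 to compound 2 (0.61 log units; beyond the scatter), and it is a modest step for a different exchange. It says little about this one, so only a small rise is expected. The expected change is a 1.5-fold higher number from compound 2 to compound 3 (0.19 log units; within the scatter). Compound 3 is estimated at 8000 nM, with an expected range of 2500 nM to 25000 nM.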

Compound 3, half-maximal inhibitory concentration: > 166000 nM
Compound 3 gave a limit, no number; the forecaster's own chance of this, stated with the estimate: 15%; at least 20-fold (1.31 log units) between middle value and limit.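

In this assay, the same atoms arranged differently matter a great deal: 3,5-dihydroxyphenyl in place of 2,3-dihydroxyphenyl gives an at least 31-fold higher number from compound 2 to compound 3 (1.50 log units; beyond the scatter). Two hydroxyl groups on the ring therefore do not guarantee a gain, since replacing 4-fluorophenyl with 3,5-dihydroxyphenyl gives an at least 7.9-fold higher number from compound 1 to compound 3 (0.89 log units; beyond the scatter). Compound 3 gives a limit, not a number: the limit of > 166000 nM in this assay, at which 1 of the 3 values shown sits.

On these data alone, how far the true value of compound 3 lies past that limit stays unknown. As far as these compounds go, it also stays open whether a single hydroxyl group, a methoxy group or an amine on this ring would match compound 2.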